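Sulfonamide aryl swap from compound 2 to compound 3

The source may hold more compounds than are shown below. What is called first, only, known or untested is meant among the compounds shown, and "the series" means these compounds.

Compound 1 `O=S(=O)(Nc1cc(F)cc(F)c1)c1ccc(-c2cnc(C3CC3)o2)cc1`: 2140 nM
Compound 2 `COc1cc(NS(=O)(=O)c2ccc(-c3cnc(C4CC4)o3)cc2)ccc1F`: 328 nM

In a functional assay on cells (leukaemia cell line, Homo sapiens) for inhibition, read by sulforhodamine B assay, with a stated time of 48 h (on this read-out lower numbers stand for stronger inhibition of growth and higher numbers for weaker inhibition of growth), compound 2 has the lower of the two numbers, at 328 nM. Compound 3 `Cc1cc(F)cc(NS(=O)(=O)c2ccc(-c3cnc(C4CC4)o3)cc2)c1` carries 3-fluoro-5-methylphenyl in place of 4-fluoro-3-methoxyphenyl on a sulfonamide nitrogen. Among the compounds with values here, the only measured step at this place is a 6.5-fold lower number from compound 1 to compound 2 (0.81 log units; beyond the scatter). Within the data shown here, no measured compound carries the entering group, so this is thin support. A partial return towards compound 1, which stands at 2140 nM, is expected, meaning a higher number. The expected move in this assay is a 2.4-fold higher number from compound 2 to compound 3 (0.39 log units; beyond the scatter). The estimate for compound 3 is 800 nM, with an expected range of 250 nM to 2500 nM.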

Compound 3, concentration for 50% growth inhibition: 138 nM
Compound 3: the middle estimate sits 5.8-fold (0.76 log units) above what was measured; measured number outside the range, below it.
By their numbers in this assay, from the lowest: compound 3; then compound 2; then compound 1.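

In this assay, the group on a sulfonamide nitrogen does not need the methoxy oxygen for a low number: 3-fluoro-5-methylphenyl in place of 4-fluoro-3-methoxyphenyl gives a 2.4-fold lower number from compound 2 to compound 3 (0.38 log units; beyond the scatter) and places compound 3 lowest of the three. A single change, methyl in place of fluoro on an aromatic carbon, gives a 16-fold lower number from compound 1 to compound 3 (1.19 log units; beyond the scatter) and is the large step in this set. Nothing available explains either step.

On these data alone, whether an ethyl or chloro group could stand in place of that methyl remains open. So does the effect of an amine or carboxylic acid on this aromatic ring.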